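The compounds below may be only part of what the source reports. "The series", "measured", "known", "first", "only" and "open" are said of these compounds alone.

Measured in a functional assay on MCF7 cells (Homo sapiens) for antiproliferative activity; a lower number here means a stronger inhibitor, a higher number a weaker inhibitor:
- compound 1 `CCCCOc1ccc(C(=O)Nc2cc3ccc(OC4CCN(C)CC4)c(C)c3oc2=O)cc1CC=C(C)C`: 1440 nM
- compound 2 `CC(C)=CCc1cccc(C(=O)Nc2cc3ccc(OC4CCN(C)CC4)c(C)c3oc2=O)c1`: 2100 nM

Among the compounds with values here, compound 2 lies within the scatter of compound 1, the only other compound measured. Compound 3 `CC(C)=CCc1cc(C(=O)Nc2cc3ccc(OC4CCN(C)CC4)c(C)c3oc2=O)ccc1OCCCN(C)C` is compound 2 with one change: 3-(dimethylamino)propoxy in place of hydrogen on an aromatic carbon. Within the data shown here, the one measured step bearing on this carbon, a 1.5-fold higher number from compound 1 to compound 2 (0.16 log units; within the scatter), concerns a butoxy group and stays within the scatter. Among the measured compounds shown here, no measured compound carries the new chain, so the evidence is thin, and no step beyond the scatter is expected in this assay. The expected step is a 1.2-fold lower number from compound 2 to compound 3 (0.09 log units; within the scatter). The estimate for compound 3 is 1700 nM, with an expected range of 600 nM to 4500 nM.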

Compound 3, half-maximal inhibitory concentration: 460 nM
For compound 3 the middle estimate is 3.7-fold (0.57 log units) above the measured one; the whole stated range lies above it.
By their numbers in this assay, from the lowest: compound 3; then compounds 1 and 2 (each within the scatter of the next).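

In this assay, 3-(dimethylamino)propoxy on this aromatic carbon moves the number beyond the scatter (a 4.6-fold lower number from compound 2 to compound 3 (0.66 log units; beyond the scatter)), which the butoxy group of compound 1 did not do. Dimethylamino in place of methyl on a saturated chain carbon, three bonds along the chain from an oxygen on an aromatic ring, also gives a step beyond the scatter (a 3.1-fold lower number from compound 1 to compound 3 (0.50 log units; beyond the scatter)), so the chain end matters here and not the presence of a chain alone. No measured property accounts for these steps. Going by these compounds, whether a primary amine, a piperidine or a longer chain ending in dimethylamino would keep the lower number stays open, as does the effect of a carboxylic acid at the chain end.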